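Capping the hydroxy group of compound 2 with methyl

A few compounds are considered here, and "the series" means these few. Any claim that something is new, unique, unknown or untested is made for them only; others in the source may bear on it.

Compound 1 `CC(C)Oc1cc(Oc2cnc(C(=O)N(C)C)nc2)cc(-c2nccc(=O)[nH]2)c1` and compound 2 `C[C@@H](CO)Oc1cc(Oc2cnc(C(=O)N(C)C)nc2)cc(-c2nccc(=O)[nH]2)c1` share the same core and differ only in their ether chain. In an ADME assay on microsomes from liver (Rattus norvegicus) for metabolic stability (on this read-out higher numbers stand for fast clearance and lower numbers for slow clearance), compound 1 gives < 25.4 mL/min/kg as a limit of the assay and not a number. Among the measured compounds shown here, compound 2 gives 26 mL/min/kg in this assay and so holds the only exact number so far. Compound 3 `COC[C@H](C)Oc1cc(Oc2cnc(C(=O)N(C)C)nc2)cc(-c2nccc(=O)[nH]2)c1` follows from compound 2 through methyl in place of hydrogen on an oxygen on a saturated carbon with hydroxy turning to methoxy on the chain. For the measured compounds named here, the single measured guide is an at least 1.0-fold higher number from compound 1 to compound 2 (0.01 log units; that floor lies within the scatter) and it concerns the arrival of that hydroxy group, not its capping. Its floor lies within the scatter, so it sets no size for the new change. A step within the scatter is therefore expected in this assay with a slight lean toward a higher number, and the expected move is a 1.2-fold higher number from compound 2 to compound 3 (0.09 log units; within the scatter) in size. The estimate for compound 3 is 32 mL/min/kg with 22 mL/min/kg to 60 mL/min/kg as its expected range here.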

Compound 3, clearance: 38 mL/min/kg
Beside the measured number, compound 3's estimate is 1.2-fold (0.07 log units) below it; low and high end bracket the measured number.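

In this assay, the change from hydroxy to methoxy now has a measured size, a 1.5-fold higher number from compound 2 to compound 3 (0.16 log units; within the scatter), so capping this oxygen on a saturated carbon with methyl gives a step that stays within the scatter. Methoxy in place of hydrogen on the chain reads an at least 1.4-fold higher number from compound 1 to compound 3 (0.17 log units; that floor lies within the scatter), which gives a floor and not a size. Compound 1 stands at a limit of the assay and not a number: the limit of < 25.4 mL/min/kg in this assay, at which 1 of the 3 values shown sits.

The compounds shown leave open how an ethyl cap on this oxygen, or an amine or a carboxylic acid in place of the hydroxy, would read in this assay. They also leave open whether methyl on this oxygen gives a step of the same size on a longer chain.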